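This account rests on a few compounds, and the source may have more. Where it says the series, first, only, none or still open, it means among the compounds named here.

Compound 1 `Nc1nc(N)c2c(-c3ccsc3)cn([C@@H]3O[C@H](CO)[C@@H](O)[C@H]3O)c2n1` is the starting point. Measured in a functional assay on HeLa S3 cells (Homo sapiens) for antiproliferative activity, read by XTT assay, with a stated time of 72 h (a higher number here means a weaker inhibitor, a lower number a stronger inhibitor), compound 1 gives > 20000 nM, which is a limit of the assay rather than a number. Two related compounds are also known. Compound 3 `Cc1nc(N)c2c(-c3ccsc3)cn([C@@H]3O[C@H](CO)[C@@H](O)[C@H]3O)c2n1` differs from compound 1 by a methyl in place of amino on an aromatic carbon, and in this assay compound 3 gives > 20000 nM, again a limit. Compound 2 `CNc1ncnc2c1c(-c1ccccc1)cn2[C@@H]1O[C@H](CO)[C@@H](O)[C@H]1O` gives > 20000 nM in this assay, also a limit. Within the data shown here, the one measured step, a step that the two limits leave unreadable from compound 1 to compound 3, cannot be sized because of the limit of > 20000 nM in this assay, at which 3 of the 3 values shown sit.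

Compound 4 `Nc1nc(N)c2c(-c3ccccc3)cn([C@@H]3O[C@H](CO)[C@@H](O)[C@H]3O)c2n1` has not yet been measured. Its difference from compound 1 is phenyl in place of thiophen-3-yl on an aromatic carbon. Among the measured compounds shown here, no measured step changes this part of the shared core, so the only guide is that every known value sits at the same limit. The step from compound 1 to compound 4, a step that the limit leaves unreadable from compound 1 to compound 4, is therefore expected to show no readable change. The value of compound 4 in this assay is estimated at 30000 nM, within 15000 nM to 200000 nM, most likely again reported as a limit.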

Compound 4, half-maximal inhibitory concentration: > 20000 nM
Compound 4 was reported as a limit; the forecaster's own chance of this, stated with the estimate: 85%; the middle value is on the limit's open side.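

The step from compound 1 to compound 4, phenyl in place of thiophen-3-yl, cannot be read, because neither compound gives a number, only a limit: the limit of > 20000 nM in this assay, at which 4 of the 4 values shown sit.

The compounds shown leave open which change to the shared core, if any, would give a readable value in this assay.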